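Compound 3 to compound 4: fluoro for chloro

The source may hold more compounds than are shown below. What is called first, only, known or untested is meant among the compounds shown, and "the series" means these compounds.

In a physicochemical assay for solubility (a higher number here means a more soluble compound, a lower number a less soluble compound), compound 1 `NS(=O)(=O)c1ccc(NC(=O)c2cc(Cl)ccc2O)cc1` gives > 48 ug/mL, which is a limit of the assay. Compound 2 `O=C(Nc1ccc(C(F)(F)F)cc1)c1cc(Br)ccc1O` gives < 1 ug/mL, also a limit. Compound 3 `O=C(Nc1ccc(C(F)(F)F)c(Cl)c1)c1cc(Br)ccc1O` gives < 1 ug/mL, again a limit and not a number. Two of the three measured compounds therefore rest at the limit of < 1 ug/mL in this assay, at which 2 of the 3 values shown sit, and the other rests at the limit of > 48 ug/mL in this assay, at which 1 of the 3 values shown sits.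

Compound 4 `O=C(Nc1ccc(C(F)(F)F)c(F)c1)c1cc(Br)ccc1O` carries fluoro in place of the chloro of compound 3: fluoro in place of chloro on an aromatic carbon. Among the measured compounds shown here, the one measured step is a step that the two limits leave unreadable from compound 2 to compound 3, and it offers no size to carry over. For the measured compounds named here, no other measured step bears on this change, so no step beyond the scatter is expected in this assay, and no direction can be given. The expected step is a step that the limit leaves unreadable from compound 3 to compound 4. The estimate rests on compound 3, whose limit of < 1 ug/mL is the nearest reading. For compound 4 the estimated value is 0.7 ug/mL, with an expected range from 0.2 ug/mL to 2 ug/mL, and a report of only a limit is the likely outcome.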

Compound 4, solubility: < 1 ug/mL
Compound 4: a limit, no number; the forecaster's own chance of this, stated with the estimate: 85%; the middle value does not contradict the limit.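

In this assay compound 4 gives < 1 ug/mL, a limit and not a number. The steps from compound 2 and compound 3 to compound 4 cannot be read. The compounds shown leave open how hydrogen, chloro and fluoro at this place compare in this assay.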